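A few compounds are considered here, and "the series" means these few. Any claim that something is new, unique, unknown or untested is made for them only; others in the source may bear on it.

Compound 1 `COc1ccc(Oc2ccc3cc(NC(=O)c4ccc(OC)c(-c5cccc(OC)c5)c4)c(=O)oc3c2C)cc1` and compound 2 `COc1cccc(-c2cc(C(=O)Nc3cc4ccc(Oc5ccc(C(C)(C)C)cc5)c(C)c4oc3=O)ccc2OC)c1` share one core and differ in a single place. In a functional assay on MCF7 cells (Homo sapiens) for antiproliferative activity (on this read-out higher numbers stand for weaker inhibition and lower numbers for stronger inhibition), compound 1 gives > 100000 nM, which is a limit of the assay and not a number. In this assay compound 2 likewise gives > 100000 nM, again a limit. The step from compound 1 to compound 2 a step that the two limits leave unreadable from compound 1 to compound 2 cannot be read, as shown by the limit of > 100000 nM in this assay, at which 2 of the 2 values shown sit. Compound 2 thus stands at the edge of what the assay reports, with no number to place it within the series.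

Compound 3 `COc1ccc(Nc2ccc3cc(NC(=O)c4ccc(OC)c(-c5cccc(OC)c5)c4)c(=O)oc3c2C)cc1` differs from compound 2 by (4-methoxyphenyl)amino in place of 4-(tert-butyl)phenoxy on an aromatic carbon. Within the data shown here, no measured step bears on this change: the only step between measured compounds is unreadable and both values sit at the limit, so neither a size nor a direction in this assay can be drawn from them. Given that compound 2 shows only a limit, compound 3 is expected to stay weak, with an estimated 100000 nM in the range 30000 nM to 300000 nM. Against the limit shown, the expected step is a number no higher from compound 2 to compound 3 (the limit leaves the size open).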

Compound 3, half-maximal inhibitory concentration: > 100000 nM
Compound 3 ended at the assay's limit; the forecaster's own chance of this, stated with the estimate: 70%; the middle value lies on the limit itself.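

The steps among compound 1, compound 2 and compound 3 cannot be read in this assay, each value being a limit and not a number: the limit of > 100000 nM in this assay, at which 3 of the 3 values shown sit.

The compounds shown leave open whether 4-methoxyphenoxy, 4-(tert-butyl)phenoxy or (4-methoxyphenyl)amino differ at all in antiproliferative activity.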